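From Pyridin-3-yl to 2-Carboxyphenyl on a Sulfonyl Sulfur

A few compounds are considered here, and "the series" means these few. Any claim that something is new, unique, unknown or untested is made for them only; others in the source may bear on it.

In a functional assay for inhibition, with Homo sapiens as the target (a lower number here means a stronger inhibitor, a higher number a weaker inhibitor), compound 1 `CCOCCS(=O)(=O)N[C@@H](CNC(=O)c1ccc2c(c1)C(=O)N(CCC1CCNCC1)C2)C(=O)O` gives 8 nM and compound 2 `O=C(NC[C@H](NS(=O)(=O)c1cccnc1)C(=O)O)c1ccc2c(c1)C(=O)N(CCC1CCNCC1)C2` gives 15 nM. Among the compounds with values here, these are the only two numbers so far, and they lie within the scatter of each other, so neither can be ranked over the other.

Compound 3 `O=C(NC[C@H](NS(=O)(=O)c1ccccc1C(=O)O)C(=O)O)c1ccc2c(c1)C(=O)N(CCC1CCNCC1)C2` keeps the shared core and changes one group: 2-carboxyphenyl in place of pyridin-3-yl on a sulfonyl sulfur.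

Within the data shown here, one measured step bears on this place: a 1.9-fold higher number from compound 1 to compound 2 (0.27 log units; within the scatter), with pyridin-3-yl in place of 2-ethoxyethyl. That step stayed within the scatter. Among the measured compounds shown here, it is thin evidence, as no measured compound carries the 2-carboxyphenyl group. No step beyond the scatter is therefore expected in this assay. The estimated step is a 1.2-fold higher number from compound 2 to compound 3 (0.08 log units; within the scatter). For compound 3 the expected value is 18 nM, with an estimated range of 5 nM to 60 nM.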

Compound 3, half-maximal inhibitory concentration: 15 nM
Estimate against measurement, compound 3: 1.2-fold (0.08 log units) above, and the stated range covers the measured number.
By their numbers in this assay, from the lowest: compounds 1, 2 and 3 (each within the scatter of the next).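

In this assay, 2-carboxyphenyl in place of pyridin-3-yl on the sulfonyl sulfur gives no change at the digits printed from compound 2 to compound 3 (within the scatter), and 2-carboxyphenyl in place of 2-ethoxyethyl gives a 1.9-fold higher number from compound 1 to compound 3 (0.27 log units; within the scatter). This position has now carried an open chain, an aromatic ring with a nitrogen and an aromatic ring of carbon only bearing a carboxyl group, and all three compounds remain within the scatter of one another. Nothing available explains why these groups are not told apart in this measurement.

A plain phenyl ring would show whether the carboxyl group of 2-carboxyphenyl counts for anything at this place. Going by these compounds, it also remains open whether an amine or a longer alkyl chain on the sulfonyl sulfur would stay within the scatter of these three compounds.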